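Swapping the Amide Linker for a Benzyl Acid

The compounds below may be only part of what the source reports. "The series", "measured", "known", "first", "only" and "open" are said of these compounds alone.

Compound 1 `CC(C)c1onc(-c2c(Cl)cccc2Cl)c1COc1ccc(N(C)C(=O)c2ccc(C(=O)O)cc2)c(C(F)(F)F)n1` gives the highest maximal response of the three compounds measured in a functional assay on HEK293 cells for agonist activity at Bile acid receptor (Homo sapiens), read by a luciferase reporter (on this read-out higher numbers stand for larger maximal responses and lower numbers for smaller maximal responses), reaching 63%. Compound 2 `CC(C)c1onc(-c2c(Cl)cccc2Cl)c1COc1ccc(NC(=O)c2ccc(C(=O)O)cc2)c(C(F)(F)F)n1` gives 48% and compound 3 `Cc1nc(OCc2c(-c3c(Cl)cccc3Cl)noc2C(C)C)ccc1N(C)C(=O)c1ccc(C(=O)O)cc1` gives 49%; the steps of a number 15 percentage points lower from compound 1 to compound 2 (beyond the scatter) and a number 14 percentage points lower from compound 1 to compound 3 (beyond the scatter) are both modest decreases. Compound 4 `CC(C)c1onc(-c2c(Cl)cccc2Cl)c1COc1ccc(N(C)Cc2ccc(CCC(=O)O)cc2)c(C(F)(F)F)n1` differs from compound 1 by 4-(2-carboxyethyl)benzyl in place of (4-carboxyphenyl)carbonyl on a nitrogen on an aromatic ring. Neither measured step touches this part of the molecule, so no direct guide exists; the two known changes each cost compound 1 a modest share of its response, and this change is larger. Compound 4 is therefore expected to show a step of a number 18 percentage points lower from compound 1 to compound 4 (beyond the scatter), a decrease beyond the scatter. The estimated value of compound 4 in this assay is 45%, between 20% and 70%.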

Compound 4, largest response reached (reported as efficacy), in percent of the reference or control that the assay uses: 66%
The estimate for compound 4 lay 21 percentage points below the measured number; the range from low to high includes it.
By their numbers in this assay, from the lowest: compounds 2 and 3 (each within the scatter of the next); then compounds 1 and 4 (each within the scatter of the next).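

In this assay, the change to 4-(2-carboxyethyl)benzyl in place of (4-carboxyphenyl)carbonyl gives a number 3 percentage points higher from compound 1 to compound 4 (within the scatter). The maximal response therefore holds on this nitrogen without the carbonyl and with a different chain carrying the acid, unlike the two earlier changes, each of which lowered it beyond the scatter. No evidence at hand explains why the response holds.

Going by these compounds, it remains open whether a shorter chain, as in 4-carboxybenzyl, or a tetrazole in place of the carboxylic acid would hold the response. Also open, on these data alone, is whether hydrogen in place of methyl on this nitrogen would lower the response with the benzyl group as it did with the amide.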